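Ring nitrogen substituent: acetyl in place of 4-hydroxybenzyl

The source may report more compounds than this note shows. Statements on the series, on what has been measured and on what is new or still open speak of the compounds shown alone.

Measured so far:
compound 1, `COC(=O)C1CN(C(C)C)CC[C@@H]1c1ccc(Cl)cc1`: 1840 nM in an assay for inhibition of Norepinephrine transporter (Rattus norvegicus); on this read-out lower numbers stand for stronger inhibition and higher numbers for weaker inhibition
compound 2, `COC(=O)C1CN(Cc2ccc(O)cc2)CC[C@@H]1c1ccc(Cl)cc1`: 1080 nM in this assay

Compound 2 carries the lowest of the two numbers, yet the gap a 1.7-fold lower number from compound 1 to compound 2 (0.23 log units; within the scatter) lies within the scatter, so the two are not separated. Compound 3 is `COC(=O)C1CN(C(C)=O)CC[C@@H]1c1ccc(Cl)cc1`; it differs by acetyl in place of 4-hydroxybenzyl on an amine nitrogen in a ring. For the measured compounds named here, the only measured step at this nitrogen swapped isopropyl for 4-hydroxybenzyl and stayed within the scatter; no measured step introduces an acetyl, so the data give no direct guide. Compound 3 is expected to show a weaker number in this assay, a step of a 7.4-fold higher number from compound 2 to compound 3 (0.87 log units; beyond the scatter), estimated at 8000 nM with a range of 1500 nM to 40000 nM.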

Compound 3, inhibition constant: > 10000 nM
Compound 3 was reported as a limit; the forecaster's own chance of this, stated with the estimate: 20%; middle value at least 1.2-fold (0.09 log units) from the limit.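

In this assay, the substituent on the amine nitrogen in the ring now matters: isopropyl and 4-hydroxybenzyl were not separated, whereas acetyl gives an at least 9.2-fold higher number from compound 2 to compound 3 (0.96 log units; beyond the scatter) and an at least 5.4-fold higher number from compound 1 to compound 3 (0.73 log units; beyond the scatter). Both steps are beyond the scatter, so the change is real, but only its lower bound can be read. Compound 3 stands at a limit, not at a number: the limit of > 10000 nM in this assay, at which 1 of the 3 values shown sits.

Still open, going by these compounds, is how far compound 3 lies beyond that limit. Also open, on these data alone, is whether the carbonyl drives the step, which a longer acyl chain, a methyl group or the free ring amine at this nitrogen would test.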